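Removing the aryl methoxy in a piperazine-linked oxazole series

The compounds below may be only part of what the source reports. "The series", "measured", "known", "first", "only" and "open" are said of these compounds alone.

Measured so far:
compound 1 `CCCc1nc(-c2ccccc2)c(CNCCN2CCN(c3cccc(C)c3)CC2)o1` — 43.1%
compound 2 `CCCc1nc(-c2ccccc2)c(CNCCN2CCN(c3cccc(OC)c3)CC2)o1` — 40.2%

In an assay on HEK293 cells for inhibition of Voltage-dependent T-type calcium channel subunit alpha-1G (Homo sapiens), read by fluorescence, tested at 10 uM (a lower number here means less inhibition, a higher number more inhibition at the concentration tested (going by the name of the read-out)), compound 1 gives 43.1%. Compound 2 gives 40.2% in this assay. Among the measured compounds shown here, the only measured step, a number 2.9 percentage points lower from compound 1 to compound 2 (within the scatter), lies within the scatter, so compound 2 holds the lower of the two numbers without any ordering being meaningful.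

Compound 3 `CCCc1nc(-c2ccccc2)c(CNCCN2CCN(c3ccccc3)CC2)o1` differs from compound 2 by hydrogen in place of methoxy on an aromatic carbon. For the measured compounds named here, the one step that bears on this change, a number 2.9 percentage points lower from compound 1 to compound 2 (within the scatter), concerns the same aromatic carbon and was within the scatter; no step beyond the scatter is therefore expected here. Compound 3 is estimated to give 38%, between 22% and 54%, an expected step of a number 2.2 percentage points lower from compound 2 to compound 3 (within the scatter).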

Compound 3, a percentage reported as inhibition, at one concentration (the size of the read-out at that concentration, not a potency): 54.3%
Beside the measured number, compound 3's estimate is 16.3 percentage points below it, and the stated range ends below it.
By their numbers in this assay, from the lowest: compounds 2 and 1 (each within the scatter of the next); then compound 3.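

In this assay the change to hydrogen gives a number 14.1 percentage points higher from compound 2 to compound 3 (beyond the scatter) and likewise a number 11.2 percentage points higher from compound 1 to compound 3 (beyond the scatter) while methoxy and methyl on this aromatic carbon could not be told apart. The difference seen so far at this position is therefore between hydrogen and either group, not between the two groups. Nothing available explains the step.

As far as these compounds go, whether fluorine, chlorine or ethoxy on this carbon would group with methyl and methoxy remains open. Also open, from the compounds shown here alone, is whether hydrogen would give a similar step with a different chain on the shared core.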